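Moving fluorine around the phenyl ring on the piperidine

The source may report more compounds than this note shows. Statements on the series, on what has been measured and on what is new or still open speak of the compounds shown alone.

Compound 2 `N#Cc1c(N2CCC(c3ccccc3F)CC2)ccn(CC2CC2)c1=O` gives 282% in a functional assay on CHO cells for positive allosteric modulation of metabotropic glutamate receptor 2 (Homo sapiens), with a stated time of 30 min (a higher number here means a larger maximal response, a lower number a smaller maximal response), the higher of the two values seen so far; compound 1 `CC(C)CCn1ccc(-c2ccccc2)c(C#N)c1=O` gives 135% there, a difference beyond the usual scatter. Compound 3 `N#Cc1c(N2CCC(c3cc(F)cc(F)c3)CC2)ccn(CC2CC2)c1=O` differs from compound 2 in one place: 3,5-difluorophenyl in place of 2-fluorophenyl on a saturated ring carbon. Within the data shown here, with no comparable pair measured, the size of this change is uncertain, and only a small shift, if any beyond the scatter, is expected. Compound 3 is therefore estimated to give 250% in this assay, within 160% to 340%. The expected step is a number 32 percentage points lower from compound 2 to compound 3 (beyond the scatter).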

Compound 3, largest response reached (Emax), in percent of the reference or control that the assay uses: 234%
Estimate against measurement, compound 3: 16 percentage points above; low and high end bracket the measured number.
By their numbers in this assay, from the lowest: compound 1; then compound 3; then compound 2.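

Swapping the group on this saturated ring carbon gives a number 48 percentage points lower from compound 2 to compound 3 (beyond the scatter) in this assay as the read-out, so the maximal response depends on how fluorine is arranged on this phenyl ring and not only on a fluorinated phenyl ring being present. Nothing measured here accounts for this step.

Going by these compounds, the step removes 2-fluorophenyl and brings in 3,5-difluorophenyl at once, so it remains open whether the lost fluorine or the two new ones matter more. A plain phenyl group on this carbon would give a reference for both.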